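The compounds below may be only part of what the source reports. "The series", "measured", "known", "first", "only" and "open" are said of these compounds alone.

Working notes on the series. Compound 1 `COc1cc(/C=C/c2ccc(OC(F)(F)F)cc2)ccc1/C=C/c1ccc(OC(F)(F)F)cc1` and compound 2 `Oc1cc(/C=C/c2ccc(OC(F)(F)F)cc2)ccc1/C=C/c1ccc(OC(F)(F)F)cc1` share one core, compound 3 `COc1ccc(/C=C/c2ccc(/C=C/c3ccc(OC)c(C(F)(F)F)c3)cc2O)cc1` and compound 4 `COc1ccc(/C=C/c2ccc(/C=C/c3ccc(OC)c(C(F)(F)F)c3)cc2OC)cc1` another; the difference between the two cores is not broken down here. In a physicochemical assay for lipophilicity, read by HPLC (on this read-out higher numbers stand for higher lipophilicity and lower numbers for lower lipophilicity), compound 1 reports only a limit, > 7. In this assay compound 2 likewise reports only a limit, > 7. Among the measured compounds shown here, compound 3 gives 7.17 in this assay, the one number in the set, since the limit of > 7 in this assay, at which 2 of the 3 values shown sit, holds the other two. The change from compound 2 to compound 1, (methyl in place of hydrogen on an oxygen on an aromatic ring), gave a step that the two limits leave unreadable from compound 2 to compound 1. The same change, (methyl in place of hydrogen on an oxygen on an aromatic ring), is not yet measured for compound 4. Because the measured pair gives a step that the two limits leave unreadable from compound 2 to compound 1, the expectation rests on compound 3 alone at 7.17 and on the one carbon that enters. Compound 4 is expected at 7.5, a step of a number 0.33 log units higher from compound 3 to compound 4 (beyond the scatter), between 7.1 and 7.9, and a limit may well recur.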

Compound 4, partition coefficient: > 7
Compound 4 ended at the assay's limit; the forecaster's own chance of this, stated with the estimate: 55%; the middle value is on the limit's open side.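

Compound 4 reports only a limit in this assay, so no step from compound 3 to it can be read: the limit of > 7 in this assay, at which 3 of the 4 values shown sit.

Going by these compounds, the size of the hydroxy to methoxy change stays open in both the core of compound 1 and the core of compound 3.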